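The source may report more compounds than this note shows. Statements on the series, on what has been measured and on what is new or still open speak of the compounds shown alone.

In an ADME assay on MT4 cells (Homo sapiens) for cytotoxicity (on this read-out lower numbers stand for higher toxicity in this test and higher numbers for lower toxicity in this test), compound 1 `O=C(NC(=S)Nc1cccc(C(F)(F)F)c1)c1ccccc1` gives > 100000 nM, which is a limit and not a number. Compound 2 `O=C(NC(=S)Nc1cccc(C(F)(F)F)c1)[C@H]1C[C@@H]2CC[C@H]1C2` gives a true number, 42000 nM. Compound 3 `CC(=O)NC(=S)Nc1cccc(C(F)(F)F)c1` gives > 100000 nM, again a limit and not a number. Compound 3 therefore sits at the limit of > 100000 nM in this assay, at which 2 of the 3 values shown sit.

The next structure, compound 4 `Fc1cccc(NC(=S)Nc2cccc(C(F)(F)F)c2)c1`, carries 3-fluorophenyl in place of acetyl on an amide-type nitrogen. The measured steps bear on this change only loosely, since each of them swaps a group on a carbonyl carbon and none removes the carbonyl. Two of them can be sized, an at least 2.3-fold lower number from compound 1 to compound 2 (0.37 log units; beyond the scatter) and an at least 2.3-fold higher number from compound 2 to compound 3 (0.37 log units; beyond the scatter). The third, a step that the two limits leave unreadable from compound 1 to compound 3, cannot be sized. Among the compounds with values here, compound 2 is thus the only compound that comes off the limit, while compound 1 goes against any idea that a larger group always lowers the number. A modest fall is still expected, of about the size seen with compound 2, and compound 4 may well stay at the limit. The expected change is an at least 2.2-fold lower number from compound 3 to compound 4 (0.34 log units; beyond the scatter). For compound 4 the estimated value is 45000 nM, with an expected range from 15000 nM to 100000 nM.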

Compound 4, half-maximal cytotoxic concentration: 20000 nM
Compound 4: the middle estimate sits 2.3-fold (0.35 log units) above what was measured; the measured number falls inside the stated range.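

In this assay, putting 3-fluorophenyl in place of acetyl on the amide-type nitrogen gives an at least 5.0-fold lower number from compound 3 to compound 4 (0.69 log units; beyond the scatter), and this is the first step shown in which the carbonyl group itself leaves that nitrogen, where the earlier steps only swapped the group on the carbonyl carbon. Compound 3 gives > 100000 nM, which is a limit and not a number, so this step has a floor but no exact size. Compound 4 is the second compound, after compound 2, to give a true number, so the shared core can come off the limit without any carbonyl on this nitrogen, and a larger group goes with a lower number in these two compounds, while compound 1 goes against that pattern.

The compounds shown leave open what the fluorine contributes, as a plain phenyl on this same nitrogen would be needed to separate its part from that of the ring. They also leave open how a butyl chain or a ring carrying an amine would read here, with much of the series still unresolved: the limit of > 100000 nM in this assay, at which 2 of the 4 values shown sit.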